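This account rests on a few compounds, and the source may have more. Where it says the series, first, only, none or still open, it means among the compounds named here.

Working notes on the hydroxamic acid series.

Of the compounds shown here, two have been measured in an assay on isolated protein for inhibition of protein deacetylase HDAC6 (Homo sapiens), read by fluorescence, with a stated time of 90 min; a lower number here means a stronger inhibitor, a higher number a weaker inhibitor. Compound 1 `O=C(NO)c1ccc(CN(Cc2nnnn2C2CCCCC2)C(=O)c2ccccc2)cc1` gives 70 nM. Compound 2 `O=C(NO)c1ccc(CN(Cc2nnnn2Cc2ccccc2)C(=O)c2ccccc2)cc1`, which carries benzyl in place of cyclohexyl on the aromatic nitrogen, gives 30 nM; this single measured step is a 2.3-fold lower number from compound 1 to compound 2 (0.37 log units; beyond the scatter). Among the compounds with values here, compound 1 therefore stands at the highest of the two numbers so far, with compound 2 as its only neighbour.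

Compound 3 `Cc1ccccc1C(=O)N(Cc1ccc(C(=O)NO)cc1)Cc1nnnn1C1CCCCC1` is not yet measured. Relative to compound 1 the change is methyl in place of hydrogen on an aromatic carbon; read one bond further out, benzoyl becomes (2-methylphenyl)carbonyl. Within the data shown here, no measured step bears on this change: the only step known, from compound 1 to compound 2, alters the substituent on the aromatic nitrogen of the tetrazole, not the benzoyl ring. There is thus no basis in this series for expecting a shift beyond the scatter in either direction. Compound 3 is accordingly expected to give about 70 nM in this assay, within a range from 30 nM to 160 nM. The step this estimate implies is no change at the digits printed from compound 1 to compound 3 (within the scatter), essentially no change expected.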

Compound 3, half-maximal inhibitory concentration: 60 nM
For compound 3 the middle estimate is 1.2-fold (0.07 log units) above the measured one; the range from low to high includes it.
By their numbers in this assay, from the lowest: compounds 2, 3 and 1 (each within the scatter of the next, the first and the last beyond it).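

The step on the benzoyl side reads, in this assay, as a 1.2-fold lower number from compound 1 to compound 3 (0.07 log units; within the scatter), for methyl in place of hydrogen on an aromatic carbon, ortho to a large group. Within the data shown here, this is the first reading on that side of the molecule, since the earlier step from the cyclohexyl to the benzyl compound concerned only the substituent on the aromatic nitrogen: at this position, on the core of compound 1, adding this single carbon does not move the number beyond the scatter. No measurement is available that would explain this reading or relate it to any property of the methyl group.

On these data alone, one methyl at one position says little about the wider scope of this ring, so it remains open what a methoxy group, a chlorine atom, an amine or a carboxylic acid would do in place of that methyl. As far as these compounds go, it is also open whether the (2-methylphenyl)carbonyl group would read the same way with benzyl on the aromatic nitrogen, as in compound 2, where the number starts from a different value.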